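A few compounds are considered here, and "the series" means these few. Any claim that something is new, unique, unknown or untested is made for them only; others in the source may bear on it.

Series notes. In a functional assay on CHO cells for antagonist activity at Orexin receptor type 2 (Homo sapiens), read by FLIPR and calcium flux (on this read-out higher numbers stand for weaker inhibition and lower numbers for stronger inhibition), compound 1 `CCn1nc(C)c2c1CCN(C(C(=O)NC)c1ccccc1)C2CCc1ccc(Cl)cc1` gives 12 nM. Compound 2 `CCn1nc(C)c2c1CCN(C(C(=O)NC)c1ccccc1)C2CCc1ccccc1F` gives 22 nM in this assay. These two numbers lie within the scatter of each other, as a 1.8-fold higher number from compound 1 to compound 2 (0.26 log units; within the scatter) shows, so neither compound can be ranked over the other. Compound 3 `CCn1nc(C)c2c1CCN(C(C(=O)NC)c1ccccc1)C2CCc1cccc(F)c1` has not yet been measured in this assay. It differs from compound 2 by 3-fluorophenyl in place of 2-fluorophenyl on a saturated chain carbon, two bonds along the chain from a saturated ring carbon. Among the compounds with values here, the only measured step at this place, a 1.8-fold higher number from compound 1 to compound 2 (0.26 log units; within the scatter), is a different exchange of the aryl group and stayed within the scatter; no measured pair sets 2-fluorophenyl against 3-fluorophenyl directly. On that basis no shift beyond the scatter is expected in this assay on going from compound 2 to compound 3, the expected step being a 1.1-fold lower number from compound 2 to compound 3 (0.04 log units; within the scatter). The value estimated for compound 3 in this assay is 20 nM, within a range from 8 nM to 50 nM.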

Compound 3, half-maximal inhibitory concentration: 10 nM
Estimate against measurement, compound 3: 2.0-fold (0.30 log units) above, within the range that was stated.
By their numbers in this assay, from the lowest: compounds 3, 1 and 2 (each within the scatter of the next, the first and the last beyond it).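

In this assay, within the data shown here, 3-fluorophenyl in place of 2-fluorophenyl on a saturated chain carbon gives a 2.2-fold lower number from compound 2 to compound 3 (0.34 log units; beyond the scatter), the first step at this place to pass the scatter, though only modestly, and it involves the same atoms, joined differently. 3-Fluorophenyl in place of 4-chlorophenyl gives a 1.2-fold lower number from compound 1 to compound 3 (0.08 log units; within the scatter), so these two aryl groups cannot be ranked against each other, and compound 1 remains within the scatter of both fluorinated compounds. Nothing available explains the difference between the two fluorophenyl groups.

The compounds shown leave open how far this aryl group can depart from a halogen-bearing phenyl, which a plain phenyl, an amine or a carboxylic acid in its place would test. A longer chain carrying 3-fluorophenyl also remains an open case.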